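A Methyl Added to the Hydroxymethyl Arm

A few compounds are considered here, and "the series" means these few. Any claim that something is new, unique, unknown or untested is made for them only; others in the source may bear on it.

Compound 1 `O=c1ccn(CCN2CCCCC2)c(CO)c1O` was examined in a physicochemical assay for acid dissociation, read by spectrophotometry, where compound 1 gives 2.2. Among the compounds with values here, of the two compounds measured so far, this is the lower number. The other, compound 2 `CCc1c(O)c(=O)ccn1CCCn1ccnc1`, gives 3.15 in this assay; its value lies above that of compound 1 by a gap beyond the scatter of the method, but the two compounds differ in more than one place, so no single structural step can be read from that pair.

Compound 3 `CC(O)c1c(O)c(=O)ccn1CCN1CCCCC1` has not yet been measured. It differs from compound 1 in one place: methyl in place of hydrogen on a saturated chain carbon bound to an aromatic carbon and an oxygen on a saturated carbon. Cut one bond further out, the same difference reads hydroxymethyl to 1-hydroxyethyl. The rest of the structure is unchanged.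

Within the data shown here, no step between measured compounds of this kind is available, so the expectation rests on the smallness of the change itself. Compound 3 is estimated to give 2.3 in this assay, with a range from 1.9 to 2.7. That estimate means a step of a number 0.10 log units higher from compound 1 to compound 3 (within the scatter), expected to sit within the usual scatter rather than beyond it.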

Compound 3, acid dissociation constant: 2.14
The estimate for compound 3 lay 0.16 log units above the measured number; the range from low to high includes it.
By their numbers in this assay, from the lowest: compounds 3 and 1 (each within the scatter of the next); then compound 2.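

In this assay, within the data shown here, methyl in place of hydrogen on a saturated chain carbon bound to an aromatic carbon and an oxygen on a saturated carbon gives a number 0.06 log units lower from compound 1 to compound 3 (within the scatter), the first step that can be read at this position. The earlier pair, compound 1 and compound 2, differs in more than one place and could not isolate any single change, whereas this pair shows that hydroxymethyl and 1-hydroxyethyl, on an otherwise unchanged structure, cannot be told apart by this read-out. Nothing available accounts for this result or says what it reflects.

The compounds shown leave open whether a longer chain on this same saturated carbon, such as propyl in place of the methyl, would also stay within the scatter, or whether an amine or a carboxylic acid in place of the hydroxyl of the arm would move the number beyond it. They also leave open whether the step from hydroxymethyl to 1-hydroxyethyl would read the same with a different amine at the end of the chain on the shared core.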